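Compound 3 to compound 4: terminal group of the chain

This account rests on a few compounds, and the source may have more. Where it says the series, first, only, none or still open, it means among the compounds named here.

Measured so far:
- compound 1 `CC/N=C(\S)NCCCCCn1nc(-c2ccccc2)ccc1=O`: 66.4%
- compound 2 `CC/N=C(/NC#N)NCCCCn1nc(-c2ccccc2)ccc1=O`: 58.8%
- compound 3 `C/N=C(\S)N(C)CCCCn1nc(-c2ccccc2)ccc1=O`: 17.5%

In a functional assay on the whole organism with Rattus norvegicus as the target, at a dose of 100 mg/kg (on this read-out higher numbers stand for more inhibition at the one dose given (going by the name of the read-out) and lower numbers for less inhibition), compound 3 stands lowest of the three; the nearest is compound 2, the furthest compound 1, and both steps to it lie beyond the scatter: a number 48.9 percentage points lower from compound 1 to compound 3 (beyond the scatter) and a number 41.3 percentage points lower from compound 2 to compound 3 (beyond the scatter). Compound 1 and compound 2 sit within the scatter of each other, a number 7.6 percentage points lower from compound 1 to compound 2 (within the scatter).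

Compound 4 `C/N=C(\S)NCCCCCCn1nc(-c2ccccc2)ccc1=O` is not yet measured. It differs from compound 3 in the chain terminus: a group of 7 heavy atoms (4 carbon, 2 nitrogen, 1 sulfur; no ring) in place of a group of 6 heavy atoms (3 carbon, 2 nitrogen, 1 sulfur; no ring), on a saturated chain carbon, four bonds along the chain from an aromatic nitrogen. Among the measured compounds shown here, the group that enters has the same count of heavy atoms as the group found in compound 1 at that place, so the step that bears most on it is the one from compound 1 to compound 3, run in reverse, with the step from compound 2 to compound 3 pointing the same way. For the measured compounds named here, a large rise in this assay is therefore expected for compound 4, roughly a number 37.5 percentage points higher from compound 3 to compound 4 (beyond the scatter), although the longer chain of compound 4 has no measured counterpart here. The estimate for compound 4 is 55%, with a range from 30% to 78%.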

Compound 4, a percentage reported as inhibition, in the whole organism at one dose (the size of the read-out at that dose, not a potency): 22.2%
For compound 4 the middle estimate is 32.8 percentage points above the measured one; the measured number lies below the stated range.
By their numbers in this assay, from the lowest: compounds 3 and 4 (each within the scatter of the next); then compounds 2 and 1 (each within the scatter of the next).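

In this assay the change at this position gives a number 4.7 percentage points higher from compound 3 to compound 4 (within the scatter), so the added heavy atom in the group on the saturated chain carbon does not lift the number towards those of the other two compounds. The gaps to them stay wide, with a number 36.6 percentage points lower from compound 2 to compound 4 (beyond the scatter) and a number 44.2 percentage points lower from compound 1 to compound 4 (beyond the scatter), so the heavy-atom count of the terminal group does not by itself separate these compounds. No measurement on these compounds offers an explanation for this result.

The chain and the terminal group vary together here, leaving open which of the two goes with the low numbers of compound 3 and compound 4. On these data alone, how a terminal urea, an amine or a carboxylic acid on a longer chain would read in this assay also remains open.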